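Extending the acyl chain on a thioglycoside thiadiazole amide

This account rests on a few compounds, and the source may have more. Where it says the series, first, only, none or still open, it means among the compounds named here.

Compound 1 `CCCCCCCCCC(=O)Nc1nnc(S[C@@H]2O[C@H](CO)[C@H](O)[C@H](O)[C@H]2O)s1` is one of three acylated thioglycoside thiadiazoles assessed in an ADME assay on CHO-K1 cells (Cricetulus griseus) for cytotoxicity, read by MTT assay, with a stated time of 24 h (on this read-out higher numbers stand for weaker inhibition and lower numbers for stronger inhibition), and in this assay compound 1 gives "not active" (no number reported), so no single number is available for it. Compound 3 `CCCCCCCC/C=C\CCCCCCCC(=O)Nc1nnc(S[C@@H]2O[C@H](CO)[C@H](O)[C@H](O)[C@H]2O)s1` likewise gives "not active" (no number reported) in this assay, a second entry without a number. Only the shorter-chain compound 2 `CCCCCCCC(=O)Nc1nnc(S[C@@H]2O[C@H](CO)[C@H](O)[C@H](O)[C@H]2O)s1` returns a figure, and in this assay compound 2 gives 60100 nM. Compound 1 therefore stands among the two entries for which the read-out gave no number rather than a measured concentration.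

The change leading to compound 4 `CCCCCCCC/C=C\CCCCCCCCCCCC(=O)Nc1nnc(S[C@@H]2O[C@H](CO)[C@H](O)[C@H](O)[C@H]2O)s1` is dodec-3-en-1-yl in place of hydrogen on a saturated chain carbon, nine bonds along the chain from a carbonyl carbon. Among the measured compounds shown here, no measured step between related pairs is available to size this change. Since compound 1 gives "not active" (no number reported) and compound 3 gives "not active" (no number reported), both long-chain amides without a number, any step from compound 1 to compound 4 is expected to stay within the scatter, with no clear direction. Compound 4 is estimated at 100000 nM, within a range of 40000 nM to 300000 nM, and a result without a number is expected to be the more likely outcome.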

Compound 4, half-maximal inhibitory concentration: "not active" (no number reported)
For compound 4 the study gives words and no number, and the estimate cannot be compared.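

Compound 1 and compound 4 both come without a number in this assay, so no step can be read between them. The compounds shown leave open whether adding the dodec-3-en-1-yl chain changes this read-out at all. Nothing shown here bears on the result.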